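Compound 1: difluoromethoxy in place of methyl

The source may report more compounds than this note shows. Statements on the series, on what has been measured and on what is new or still open speak of the compounds shown alone.

In an ADME assay on cells (Hepatocyte, Homo sapiens) for metabolic stability (on this read-out lower numbers stand for slow clearance and higher numbers for fast clearance), compound 1 `COc1cccc2nnn(CC(=O)N[C@@H](C)c3ccc(C)cc3)c(=O)c12` gives 16 mL/min/kg, the lower of the two numbers available. Compound 2 `Cc1ccc([C@H](C)NC(=O)Cn2nnc3ccc(C)cc3c2=O)cc1` gives 33 mL/min/kg, a gap just beyond the scatter. Compound 4 `COc1cccc2nnn(CC(=O)N[C@@H](C)c3ccc(OC(F)F)cc3)c(=O)c12` keeps the core of compound 1 and carries difluoromethoxy in place of methyl on an aromatic carbon, para to a large group: difluoromethoxy in place of methyl on an aromatic carbon. Among the measured compounds shown here, no measured pair isolates this change. For the measured compounds named here, the only hint is compound 3 `C[C@H](NC(=O)Cn1nnc2ccccc2c1=O)c1ccc(OC(F)(F)F)cc1F`, which also bears a fluorinated ether but differs elsewhere and reads < 5.7 mL/min/kg, a limit of the assay and not a number. A modest drop in this assay, about the size of the scatter, is therefore expected. The expected change is a 1.8-fold lower number from compound 1 to compound 4 (0.25 log units; within the scatter). For compound 4 the estimate is 9 mL/min/kg, within an expected range of 5.5 mL/min/kg to 17 mL/min/kg.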

Compound 4, clearance in the Hepatocyte assay: < 4.7 mL/min/kg
Compound 4 was reported as a limit (the forecaster's own chance of this, stated with the estimate: 20%); at least 1.9-fold (0.28 log units) between middle value and limit.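

Among the compounds shown here, in the Hepatocyte assay compound 1 gives 16 mL/min/kg, and the first matched pair for difluoromethoxy in place of methyl, on an aromatic carbon para to a large group, gives an at least 3.4-fold lower number from compound 1 to compound 4 (0.53 log units; beyond the scatter). In the Hepatocyte assay compound 4 gives < 4.7 mL/min/kg, a limit of the assay and not a number, so the full size of this step stays unresolved: the limit of < 4.7 mL/min/kg in the Hepatocyte assay, at which 1 of the 4 values shown sits. In a physicochemical assay for solubility, read by HPLC, in phosphate buffer, with a stated time of 16 h, at pH 6.8 (a higher number here means a more soluble compound, a lower number a less soluble compound), compound 1 gives 9300 nM and compound 4 gives 9600 nM. In the physicochemical assay the same exchange gives a 1.0-fold higher number from compound 1 to compound 4 (0.01 log units; within the scatter), so the two compounds stand level on this read-out.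

As far as these compounds go, whether a nitrile or a chlorine atom at this place would read like difluoromethoxy stays open. From the compounds shown here alone, whether the step carries over to a different core also stays open.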